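The source may hold more compounds than are shown below. What is called first, only, known or untested is meant among the compounds shown, and "the series" means these compounds.

Measured so far:
- compound 1, `COc1nonc1/C(=N/O)Nc1ccc(F)c(Br)c1`: 230 nM
- compound 2, `O=C(NCCSc1nonc1/C(=N/O)Nc1ccc(F)c(C(F)F)c1)C1CS(=O)(=O)C1`: 70 nM

Of the compounds shown here, two have been tested in an assay for inhibition of Indoleamine 2,3-dioxygenase 1 (Homo sapiens), read by fluorescence, with a stated time of 1 h; on this read-out lower numbers stand for stronger inhibition and higher numbers for weaker inhibition. Compound 1, `COc1nonc1/C(=N/O)Nc1ccc(F)c(Br)c1`, gives 230 nM and stands highest of the two numbers. Its nearest neighbour is compound 2, `O=C(NCCSc1nonc1/C(=N/O)Nc1ccc(F)c(C(F)F)c1)C1CS(=O)(=O)C1`, which in this assay gives 70 nM, a number lower than that of compound 1 by a gap that lies beyond the usual scatter. The two compounds differ in more than one place, so the gap between them cannot be assigned to any single change.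

The next compound, compound 3, `CSc1nonc1/C(=N/O)Nc1ccc(F)c(Br)c1`, is a single-point variant of compound 1: methylsulfanyl in place of methoxy on an aromatic carbon of the shared core. Going by the values given here, no measured pair shows this exact exchange, so its effect is not known from the data at hand. Compound 3 is expected to land close to compound 1, with at most a small step toward a lower number, a 1.5-fold lower number from compound 1 to compound 3 (0.19 log units; within the scatter), and quite possibly a step that stays within the scatter. Compound 3 is therefore estimated at 150 nM, with a range from 60 nM to 450 nM.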

Compound 3, half-maximal inhibitory concentration: 560 nM
Compound 3: middle estimate off by 3.7-fold (0.57 log units), on the low side, outside the stated range (above it).
By their numbers in this assay, from the lowest: compound 2; then compound 1; then compound 3.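

In this assay, methylsulfanyl in place of methoxy on an aromatic carbon of the shared core gives a 2.4-fold higher number from compound 1 to compound 3 (0.39 log units; beyond the scatter), a modest step but one beyond the scatter, and it is the only change among the compounds shown that can be read on its own. The position therefore responds to this exchange, even though the two groups have the same count of heavy atoms, hydrogen-bond donors and hydrogen-bond acceptors, neither has a ring or a net charge, and the only difference in those counts is sulfur in place of oxygen. The data at hand offer no independent measurement that would account for this step.

Going by these compounds, with a single exchange to go on, it remains open how an amine, an ethoxy group or a longer alkyl chain would stand at this position relative to methoxy. On these data alone, it also remains open whether the same exchange would give a step of similar size and direction on a core that carries a different group elsewhere.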